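Chloro for Fluoro on a Hydroxamic Acid Core

The source may hold more compounds than are shown below. What is called first, only, known or untested is meant among the compounds shown, and "the series" means these compounds.

Measured compounds:
- Compound 1, `O=C(CCC1=CCN(Cc2ccc(F)cc2)C1=O)NO`, gives 6060 nM in a functional assay on NUGC-3 cells (Homo sapiens) for inhibition, read by sulforhodamine B assay; a higher number here means a weaker inhibitor of growth, a lower number a stronger inhibitor of growth.
- Compound 2, `Cc1ccc(CCCCN2CC=C(CCC(=O)NO)C2=O)cc1`, gives 3530 nM in this assay.
- Compound 3, `O=C(CCC1=CCN(Cc2cccc(Br)c2)C1=O)NO`, gives 4280 nM in this assay.

Three compounds share the hydroxamic acid core and differ only in the group on the ring nitrogen. Among the numbers shown, compound 1 has the highest, yet its gap to compound 3 and its gap to compound 2 both fall within the usual scatter, so the three cannot be separated by these data alone, and no ordering is claimed.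

Compound 4, `O=C(CCC1=CCN(Cc2ccc(Cl)cc2)C1=O)NO`, has not yet been measured. It differs from compound 1 in one place:

chloro in place of fluoro on an aromatic carbon

Within the data shown here, no measured pair shows this same change, so nothing in the data fixes its size. The expected step in this assay is a 1.3-fold lower number from compound 1 to compound 4 (0.13 log units; within the scatter), which stays within the scatter rather than beyond it. Compound 4 is therefore estimated at 4500 nM, with a range from 2000 nM to 10000 nM.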

Compound 4, concentration for 50% growth inhibition: 4280 nM
The estimate for compound 4 lay 1.1-fold (0.02 log units) above the measured number; the measured number falls inside the stated range.
By their numbers in this assay, from the lowest: compounds 2, 3, 4 and 1 (each within the scatter of the next).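

Chloro in place of fluoro, on an aromatic carbon para to a large group, gives a 1.4-fold lower number from compound 1 to compound 4 (0.15 log units; within the scatter) in this assay and so provides the first pair in this set that differs in one place. At this position, then, replacing one single-atom group with the other leaves the number within the scatter, and this pair gives no sign that the assay separates fluoro from chloro. The data offer nothing that would account for this result.

Going by these compounds, whether an amine or a carboxylic acid on that same aromatic carbon would carry the number beyond the scatter remains open. On these data alone, it is equally open whether a longer chain on the ring nitrogen, with chloro kept in place, would do so.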